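The source may hold more compounds than are shown below. What is called first, only, known or untested is meant among the compounds shown, and "the series" means these compounds.

Measured in a functional assay on MCF7 cells (Homo sapiens) for antiproliferative activity, read by MTT assay, with a stated time of 72 h; on this read-out lower numbers stand for stronger inhibition and higher numbers for weaker inhibition:
- compound 1 `O=C1COc2ccc(-c3cnc(Cl)c(NS(=O)(=O)c4ccc(F)cc4)c3)cc2N1c1ccc(F)cc1`: 32600 nM
- compound 2 `Cc1ccc(N2C(=O)COc3ccc(-c4cnc(Cl)c(NS(=O)(=O)c5ccc(F)cc5)c4)cc32)cc1`: 32600 nM
- compound 3 `O=C1COc2ccc(-c3cnc(Cl)c(NS(=O)(=O)c4ccc(F)cc4)c3)cc2N1c1ccccc1`: > 40000 nM (a limit, not a number)

Compound 3 stands at the limit of > 40000 nM in this assay, at which 1 of the 3 values shown sits. Compound 4 `O=C1COc2ccc(-c3cnc(Cl)c(NS(=O)(=O)c4ccc(F)cc4)c3)cc2N1C1CC1` carries cyclopropyl in place of phenyl on an amide-type nitrogen in a ring.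

The nearest evidence is indirect, since all measured steps are exchanges on an aromatic carbon and none replaces the phenyl itself. The step of no change at the digits printed from compound 1 to compound 2 (within the scatter) is one. The other two are an at least 1.2-fold higher number from compound 1 to compound 3 (0.08 log units; that floor lies within the scatter) and an at least 1.2-fold higher number from compound 2 to compound 3 (0.08 log units; that floor lies within the scatter), whose floors give no measured size beyond the scatter.

On these steps, no change beyond the scatter is expected in this assay, and no direction can be set with confidence. A result reported only as a limit is quite possible.

The expected step is an at least 1.3-fold lower number from compound 3 to compound 4 (0.12 log units; that floor lies within the scatter).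

For compound 4 the estimated value is 30000 nM, with an expected range of 12000 nM to 60000 nM.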

Compound 4, half-maximal inhibitory concentration: 16700 nM
Beside the measured number, compound 4's estimate is 1.8-fold (0.25 log units) above it; the range from low to high includes it.
By their numbers in this assay, from the lowest: compounds 4, 1 and 2 (each within the scatter of the next). At a limit, above all of these: compound 3.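

In this assay, among the compounds shown here, the earlier compounds varied only a substituent on the aromatic ring held by the amide-type nitrogen, whereas compound 4 replaces that ring, and the position accepts a non-aromatic cyclopropyl with activity kept: the step is an at least 2.3-fold lower number from compound 3 to compound 4 (0.37 log units; beyond the scatter). That size is only a floor, since compound 3 carries a limit of the assay and not a number: the limit of > 40000 nM in this assay, at which 1 of the 4 values shown sits. Against the substituted rings the change reads a 2.0-fold lower number from compound 2 to compound 4 (0.29 log units; within the scatter) and a 2.0-fold lower number from compound 1 to compound 4 (0.29 log units; within the scatter), so the difference beyond the scatter holds only against unsubstituted phenyl.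

On these data alone, it remains open whether a larger saturated ring such as cyclohexyl, or a longer chain such as n-butyl, on this nitrogen would move the number beyond the scatter of compound 4. A chain ending in an amine or a carboxylic acid at this position is also untested in the compounds shown.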